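Adding a Methyl Group to the Core of Compound 3

This account rests on a few compounds, and the source may have more. Where it says the series, first, only, none or still open, it means among the compounds named here.

Of the compounds shown here, three have been measured in an in vitro assay on 293-EBNA cells for binding affinity to corticotropin-releasing factor receptor 1 (Homo sapiens); a lower number here means a stronger inhibitor, a higher number a weaker inhibitor. Compound 1 `CCCCN(CC)c1nc(C)nc2c1nnn2-c1ccc(C(C)C)cc1Br` gives 7.5 nM. Compound 2 `CCCCN(CC)c1nc(C)nc2c1ncn2-c1c(Br)cc(OC)cc1OC` gives 3.5 nM, and compound 3 `CCCCN(CC)c1nc(C)nc2c1ncn2-c1c(Cl)cc(OC)cc1OC` gives 5.2 nM. For the measured compounds named here, compound 3 thus stands second highest of the three numbers, yet its gaps to both compound 1 and compound 2 lie within the scatter, as does the one measured step, a 1.5-fold higher number from compound 2 to compound 3 (0.17 log units; within the scatter).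

Compound 4 `CCCCN(CC)c1nc(C)nc2c1nc(C)n2-c1c(Cl)cc(OC)cc1OC` differs from compound 3 by methyl in place of hydrogen on an aromatic carbon. Going by the values given here, no measured step touches this part of the shared core, so there is no direct guide; the single measured step, a halogen swap elsewhere, produced no change beyond the scatter. With nothing pointing either way, no step beyond the scatter is expected in this assay.

Compound 4 is therefore expected to give about 5 nM, within a range from 1.5 nM to 20 nM. The expected step amounts to a 1.0-fold lower number from compound 3 to compound 4 (0.02 log units; within the scatter).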

Compound 4, inhibition constant: 3.5 nM
Beside the measured number, compound 4's estimate is 1.4-fold (0.15 log units) above it; measured number inside the range.
By their numbers in this assay, from the lowest: compounds 2, 4, 3 and 1 (each within the scatter of the next, the first and the last beyond it).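

In this assay methyl in place of hydrogen on an aromatic carbon, between two ring nitrogen atoms, gives a 1.5-fold lower number from compound 3 to compound 4 (0.17 log units; within the scatter) and so stays within the scatter. For the compounds shown here, this is the first reading at this position, since the earlier step concerned only a halogen, and it shows that this added carbon leaves the number essentially unchanged. Nothing available explains this outcome.

Going by these compounds, whether a longer chain such as propyl or an amine at this position would also leave the number unchanged remains open. So does whether methyl here acts the same way alongside bromo, as in compound 2.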